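This account rests on a few compounds, and the source may have more. Where it says the series, first, only, none or still open, it means among the compounds named here.

Measured compounds and their values:

- compound 1, `O=C(Nc1ccccc1)Nc1nc(Sc2c[nH]c3ccccc23)cc(N2CCN(Cc3ccccc3)CC2)n1`: in a functional assay on HepG2 cells (Homo sapiens) for inhibition, with a stated time of 72 h (on this read-out higher numbers stand for weaker inhibition and lower numbers for stronger inhibition), compound 1 gives 8160 nM
- compound 2, `Cc1cc(Cl)ccc1NC(=O)Nc1nc(Nc2ccccc2)cc(Sc2c[nH]c3ccccc23)n1`: in this assay compound 2 gives 8370 nM
- compound 3, `Cc1cc(Cl)ccc1NC(=O)Nc1nc(Sc2c[nH]c3ccccc23)cc(N2CCN(Cc3ccccc3)CC2)n1`: in this assay compound 3 gives 11700 nM

Compound 3 has the highest of the three numbers, yet all three lie within the usual scatter of one another, so the data do not separate compound 3 from compound 2 or compound 1 in any reliable way. Among the compounds with values here, the single step between compounds that differ in one place, a 1.4-fold higher number from compound 1 to compound 3 (0.16 log units; within the scatter), concerns the group on the amide-type nitrogen and is itself within the scatter.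

Compound 4, `Cc1cc(Cl)ccc1NC(=O)Nc1nc(Sc2c[nH]c3ccccc23)cc(N2CCN(c3ccccn3)CC2)n1`, differs from compound 3 by pyridin-2-yl in place of benzyl on an amine nitrogen in a ring. Within the data shown here, no measured pair touches this part of the structure, so the only guidance is the general picture: three closely related compounds that all give numbers within the scatter of one another, and one change elsewhere that moved nothing beyond the scatter. On that basis the expected step is a 1.1-fold lower number from compound 3 to compound 4 (0.03 log units; within the scatter), that is, nothing beyond the scatter in either direction. Among the measured compounds shown here, compound 4 is therefore estimated at 11000 nM, with a range from 4000 nM to 30000 nM, and the uncertainty is wide because no step in the data bears directly on the amine nitrogen in the ring.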

Compound 4, half-maximal inhibitory concentration: 7640 nM
Estimate against measurement, compound 4: 1.4-fold (0.16 log units) above; low and high end bracket the measured number.
By their numbers in this assay, from the lowest: compounds 4, 1, 2 and 3 (each within the scatter of the next).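

In this assay, putting pyridin-2-yl in place of benzyl on the amine nitrogen in the ring gives a 1.5-fold lower number from compound 3 to compound 4 (0.19 log units; within the scatter), so at this position an aromatic ring of carbon only can give way to one that carries a ring nitrogen and a hydrogen-bond acceptor without a change beyond the scatter. The whole group on the aromatic carbon of the shared core can also differ: 4-(pyridin-2-yl)piperazin-1-yl in place of anilino gives a 1.1-fold lower number from compound 2 to compound 4 (0.04 log units; within the scatter), again with no separation between the two compounds. No independent measurement is available that could explain either result.

All four compounds lie within the scatter of their neighbours in the ranking, so the compounds shown leave open whether any change around the shared core can move the number beyond the scatter. On these data alone, it also remains open what a simple methyl or acetyl group on this ring nitrogen would give, or a carboxylic acid or an amine attached to the pyridine ring.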